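Benzyl for methyl on the sulfur of a chlorinated triazole

A few compounds are considered here, and "the series" means these few. Any claim that something is new, unique, unknown or untested is made for them only; others in the source may bear on it.

Measured compounds:
Compound 1, `c1ccc(CSc2nnc(Cc3ccccc3Oc3ccccc3)[nH]2)cc1`: 139%
Compound 2, `CSc1nnc(Cc2ccc(Cl)cc2Oc2ccccc2Cl)[nH]1`: 132%
Compound 3, `CSc1nnc(Cc2ccc(Cl)cc2Oc2ccccc2F)[nH]1`: 121%

All three compounds were tested in a functional assay on the whole organism (strain NMRI) with Mus musculus as the target, with a stated time of 60 min, at a dose of 10 mg/kg by the intraperitoneal route; a higher number here means a stronger effect of the compound at the dose given, a lower number a weaker effect. Compound 3 gives the lowest of the three readings: the step of a number 11 percentage points lower from compound 2 to compound 3 (beyond the scatter) is beyond the usual scatter, and compound 1 stands higher still.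

Compound 4, `Fc1ccccc1Oc1cc(Cl)ccc1Cc1nnc(SCc2ccccc2)[nH]1`, is not yet measured. It differs from compound 3 by phenyl in place of hydrogen on a saturated chain carbon bound to a sulfur. Among the compounds with values here, no measured pair shows exactly this change. Within the data shown here, the only step measured, a number 11 percentage points lower from compound 2 to compound 3 (beyond the scatter), concerns a halogen on an aromatic ring and says nothing directly about the sulfur side chain. What the numbers do show is that compound 1, which carries the benzylsulfanyl group rather than methylsulfanyl, gives 139%, the highest of the three, though it also lacks the two halogens and so differs from compound 3 in more than one place.

On that thin basis, a modest rise is expected for compound 4, a number 7 percentage points higher from compound 3 to compound 4 (within the scatter), with wide uncertainty. Compound 4 is estimated at 128%, within 110% to 146%.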

Compound 4, a percentage reported as activity, at one dose (the size of the read-out at that dose, not a potency): 169%
For compound 4 the middle estimate is 41 percentage points below the measured one; measured number outside the range, above it.
By their numbers in this assay, from the lowest: compound 3; then compounds 2 and 1 (each within the scatter of the next); then compound 4.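

In this assay, the group on the sulfur proves to be a place where the reading can move a long way: going from methylsulfanyl to benzylsulfanyl gives a number 48 percentage points higher from compound 3 to compound 4 (beyond the scatter), a large step. Within the data shown here, this is the first comparison that isolates the sulfur side chain, and the step is much bigger than the only other one available, the change from chloro to fluoro, a number 11 percentage points lower from compound 2 to compound 3 (beyond the scatter). Nothing here bears on the reason for the rise, which stays unexplained.

Going by these compounds, it remains open whether the gain needs the phenyl ring itself, or whether a plain longer chain such as propyl on the sulfur would also give it. Also open, on these data alone, is how an amine or a carboxylic acid on the benzyl group would change the reading.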